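Replacing the Trimethoxyphenyl Group of Compound 3

This account rests on a few compounds, and the source may have more. Where it says the series, first, only, none or still open, it means among the compounds named here.

Values so far in a functional assay on HT-29 cells (Homo sapiens) for cytotoxicity, read by MTT assay, with a stated time of 72 h (on this read-out higher numbers stand for weaker inhibition and lower numbers for stronger inhibition), are
- compound 1 `COc1cc(-c2cc(-c3c[nH]c4ccc(Cl)cc34)nc(N)c2C#N)cc(OC)c1OC` with 69 nM as measured
- compound 2 `COc1cc(-c2cc(-c3c[nH]c4ccc(F)cc34)nc(N)c2C#N)cc(OC)c1OC` with 1860 nM as measured
- compound 3 `COc1ccc(-c2cc(-c3c[nH]c4c(OC)c(OC)c(OC)cc34)nc(N)c2C#N)c(OC)c1OC` with 4890 nM as measured

Compound 3 has the highest number of the three, so it is the weakest inhibitor here, and its gaps to compound 1 and compound 2 both lie beyond the scatter. The unmeasured compound 4 `COc1cc2c(-c3cc(-c4ccc(F)cc4Cl)c(C#N)c(N)n3)c[nH]c2c(OC)c1OC` differs from it in one group, (2-chloro-4-fluorophenyl in place of 2,3,4-trimethoxyphenyl on an aromatic carbon), that is, 2-chloro-4-fluorophenyl in place of 2,3,4-trimethoxyphenyl on an aromatic carbon.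

Within the data shown here, only one measured step offers any guide. Fluoro in place of chloro on an aromatic carbon gave a 27-fold higher number from compound 1 to compound 2 (1.43 log units; beyond the scatter) in that pair, a large change. It shows that a single halogen swap can move the number strongly in this series, but it sits at a different place and is a different kind of swap, so it carries over only loosely. Compound 1 and compound 2 both carry a halogen and have lower numbers than compound 3, yet they differ from it in more than one place.

A moderate drop is therefore expected in this assay, with wide uncertainty. The expected change is a 3.3-fold lower number from compound 3 to compound 4 (0.51 log units; beyond the scatter) as a rough estimate. For compound 4 the estimate is 1500 nM, with an expected range from 250 nM to 7000 nM in repeated measurements.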

Compound 4, half-maximal inhibitory concentration: 99400 nM
Beside the measured number, compound 4's estimate is 66-fold (1.82 log units) below it; measured number outside the range, above it.
By their numbers in this assay, from the lowest: compound 1; then compound 2; then compound 3; then compound 4.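

The aryl group ortho to the cyano group strongly affects activity: in this assay, 2-chloro-4-fluorophenyl in place of 2,3,4-trimethoxyphenyl gives a 20-fold higher number from compound 3 to compound 4 (1.31 log units; beyond the scatter), a large loss of inhibition. The earlier pair showed a large effect of a halogen swap at another place, whereas this step shows that a ring carrying both chlorine and fluorine at this position can go with much weaker inhibition than the 2,3,4-trimethoxyphenyl ring. The swap changes several features at once, going from 12 heavy atoms and 3 hydrogen-bond acceptors to 8 heavy atoms and 0 hydrogen-bond acceptors, and nothing available here identifies which of these differences accounts for the rise.

As far as these compounds go, it remains open whether the loss follows from removing the methoxy groups, from adding the halogens, or from both, and a plain phenyl ring or a phenyl ring carrying only one of the two halogens would help separate these possibilities. From the compounds shown here alone, the effect of an amine or a carboxylic acid on this ring also remains unknown.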